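The source may hold more compounds than are shown below. What is called first, only, known or untested is meant among the compounds shown, and "the series" means these compounds.

Compound 1 `COc1ccc2nc(C)cc(OCC(=O)NCc3cc(C)cc(C)c3)c2c1` gives 92000 nM in a physicochemical assay for solubility, in phosphate buffer, measured as kinetic solubility, with a stated time of 1 h, at pH 7.4; on this read-out higher numbers stand for higher solubility and lower numbers for lower solubility. Compound 2 `COc1ccc2nc(C)cc(OCC(=O)Nc3cc(C)ccc3C)c2c1` gives 45500 nM in this assay, a step of a 2.0-fold lower number from compound 1 to compound 2 (0.31 log units; beyond the scatter). Compound 3 `COc1ccc2nc(C)cc(OCC(=O)Nc3ccc(Br)c(C)c3)c2c1` returns only a limit in this assay, < 1000 nM. The steps of an at least 92-fold lower number from compound 1 to compound 3 (1.96 log units; beyond the scatter) and an at least 45-fold lower number from compound 2 to compound 3 (1.65 log units; beyond the scatter) place compound 3 lowest of the three, at the limit of < 1000 nM in this assay, at which 1 of the 3 values shown sits. Compound 4 `COc1ccc2nc(C)cc(OCC(=O)Nc3ccc(Cl)cc3Cl)c2c1` carries 2,4-dichlorophenyl in place of 4-bromo-3-methylphenyl on an amide-type nitrogen. Among the measured compounds shown here, no measured step exchanges one halogenated phenyl for another; the two large steps onto compound 3 show only that it sits far under compound 1 and compound 2. The estimate is therefore a step of an at least 1.2-fold higher number from compound 3 to compound 4 (0.07 log units; that floor lies within the scatter), and compound 4 is expected near 1200 nM, within 300 nM to 5000 nM, most probably reported again only as a limit.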

Compound 4, solubility: 20500 nM
Compound 4: middle estimate off by 17-fold (1.23 log units), on the low side; the whole stated range lies below it.
By their numbers in this assay, from the lowest: compound 4; then compound 2; then compound 1. At a limit, below all of these: compound 3.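

In this assay, a halogen on the phenyl at this amide-type nitrogen does not go with a low number in every case: 2,4-dichlorophenyl in place of 4-bromo-3-methylphenyl gives an at least 20-fold higher number from compound 3 to compound 4 (1.31 log units; beyond the scatter). Compound 3 is known here only as a limit: the limit of < 1000 nM in this assay, at which 1 of the 4 values shown sits. The other two steps are modest, though beyond the scatter: a 2.2-fold lower number from compound 2 to compound 4 (0.35 log units; beyond the scatter), and a 4.5-fold lower number from compound 1 to compound 4 (0.65 log units; beyond the scatter).

As far as these compounds go, the two halogenated phenyl groups differ in their halogens and in the methyl together, so which difference carries the large step stays open. Also open, from the compounds shown here alone, is how a phenyl bearing an amine or a carboxylic acid would read.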